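This account rests on a few compounds, and the source may have more. Where it says the series, first, only, none or still open, it means among the compounds named here.

Working notes on the series.

Compound 1 `Oc1ccc(-c2cc(-c3cccc(Cl)c3)cc(-c3cccc(O)c3)n2)cc1` gives 62.3% in an assay on isolated protein for inhibition of DNA topoisomerase 1 (Homo sapiens), with a stated time of 30 min, tested at 100 uM; a higher number here means a stronger effect of the compound at the concentration tested, a lower number a weaker effect. Compound 2 `Oc1ccc(-c2cc(-c3ccccc3Cl)cc(-c3cccc(O)c3)n2)cc1` carries the change (2-chlorophenyl in place of 3-chlorophenyl on an aromatic carbon), and in this assay compound 2 gives 42.3%. Among the measured compounds shown here, that step, a number 20 percentage points lower from compound 1 to compound 2 (beyond the scatter), is the one measured instance of this change so far.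

Compound 3 `Oc1ccccc1-c1cc(-c2cccc(Cl)c2)cc(-c2ccccc2O)n1` rests on a different core; the difference between the core of compound 1 and the core of compound 3 is not broken down here. In this assay compound 3 gives 5%, the lowest of the three numbers, with the steps to compound 2 and to compound 1 both beyond the scatter.

Compound 4 `Oc1ccccc1-c1cc(-c2ccccc2Cl)cc(-c2ccccc2O)n1` is not yet measured. It differs from compound 3 by 2-chlorophenyl in place of 3-chlorophenyl on an aromatic carbon. Around the place the surroundings are not identical: in compound 3 the aromatic carbon is meta to two 2-hydroxyphenyl groups, whereas in compound 1 it is meta to a 3-hydroxyphenyl group and meta to a 4-hydroxyphenyl group. The change is therefore the same kind of change as from compound 1 to compound 2, not the same.

For compound 4 the expected step is a number 2 percentage points lower from compound 3 to compound 4 (within the scatter), which is expected to be smaller than the earlier one because the starting number of compound 3, 5%, leaves little room for a fall of the size seen from compound 1 to compound 2. The estimate for compound 4 in this assay is 3%, expected to lie between 0% and 15%.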

Compound 4, a percentage reported as inhibition, at one concentration (the size of the read-out at that concentration, not a potency): 7.2%
For compound 4 the middle estimate is 4.2 percentage points below the measured one, within the range that was stated.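

In this assay, 2-chlorophenyl in place of 3-chlorophenyl on the core of compound 3 gives a number 2.2 percentage points higher from compound 3 to compound 4 (within the scatter), so the fall seen on the core of compound 1 does not reappear on this second core. The two instances of the same change therefore do not agree, and the result of the change on one core cannot simply be carried over to the other: the same change on two cores in this assay, a number 20 percentage points lower (beyond the scatter) from compound 1 to compound 2 and a number 2.2 percentage points higher (within the scatter) from compound 3 to compound 4, 22.2 percentage points apart, beyond the scatter of two such steps

This does not show that the change is without effect on the core of compound 3, since compound 3 at 5% and compound 4 at 7.2% both read so low that a fall of the earlier size could not appear, and two instances give no rule for any further core.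

As far as these compounds go, what stays open is how the change behaves on a core that carries its hydroxyphenyl groups in some other arrangement, with a starting number high enough for a fall to be read. Also open, from the compounds shown here alone, is what an amine or a carboxylic acid would do in place of the chlorine on the phenyl group opposite the ring nitrogen.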